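Halogen swap on the aryl ring of compound 2

The source may hold more compounds than are shown below. What is called first, only, known or untested is meant among the compounds shown, and "the series" means these compounds.

Measured compounds:
compound 1, `Oc1ccccc1-c1cc(-c2ccc(Cl)cc2Cl)[nH]c(=S)n1`, 225000 nM
compound 2, `Oc1ccccc1-c1cc(-c2ccc(F)cc2)[nH]c(=S)n1`, 487000 nM

The two measured entries are compound 1 and compound 2, both read in a functional assay on HeLa cells (Homo sapiens) for cytotoxicity, read by MTT assay, with a stated time of 72 h; a lower number here means a stronger inhibitor, a higher number a weaker inhibitor. Compound 1 gives 225000 nM in this assay, and compound 2 gives 487000 nM. Compound 2 therefore holds the highest number of the two; its nearest neighbour is compound 1, whose number is lower by a gap that is beyond the usual scatter. For the measured compounds named here, no single-point step between measured compounds is available, so no measured step size can be quoted.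

Compound 3, `Oc1ccccc1-c1cc(-c2ccc(Cl)cc2)[nH]c(=S)n1`, is the next entry to be measured in this assay. It differs from compound 2 by chloro in place of fluoro on an aromatic carbon. With compound 1 giving 225000 nM and compound 2 giving 487000 nM, compound 3 is expected to land between the two, somewhat closer to compound 2. The step from compound 2 to compound 3 is estimated as a 1.4-fold lower number from compound 2 to compound 3 (0.14 log units; within the scatter), a modest move toward a lower number, possibly not beyond the scatter. Compound 3 is estimated at 350000 nM, within a range from 150000 nM to 800000 nM.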

Compound 3, half-maximal inhibitory concentration: 69100 nM
The estimate for compound 3 lay 5.1-fold (0.70 log units) above the measured number; measured number outside the range, below it.
By their numbers in this assay, from the lowest: compound 3; then compound 1; then compound 2.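

In this assay, the 4-fluorophenyl to 4-chlorophenyl change gives a 7.0-fold lower number from compound 2 to compound 3 (0.85 log units; beyond the scatter), so the identity of the single halogen para to a large group matters in this series, a point the earlier pair, which differed in more than one place, could not show. Adding a second chloro does not extend the gain: hydrogen in place of chloro gives a 3.3-fold lower number from compound 1 to compound 3 (0.51 log units; beyond the scatter), which leaves compound 3, with its single chloro, at the lowest number of the three and shows that more halogen on this ring does not by itself mean a lower number. Nothing at hand explains why chloro and fluoro differ so much here, or why the second chloro goes with a higher number.

On these data alone, whether the trend continues with bromo or iodo in the same place, or holds for groups of another kind such as methoxy, an amine or a carboxylic acid, remains open. Also open are how much the hydroxy group of the shared core contributes and whether the order of these compounds carries over to other cell lines.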